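A few compounds are considered here, and "the series" means these few. Any claim that something is new, unique, unknown or untested is made for them only; others in the source may bear on it.

Of the compounds shown here, three have so far been tested in a functional assay on HOP-62 cells (Homo sapiens) for cytotoxicity, read by sulforhodamine B assay, with a stated time of 48 h, tested at 1 uM; on this read-out higher numbers stand for a weaker effect at the one concentration tested and lower numbers for a stronger effect. Compound 1 `COc1ccc(-c2cc(/C=C/C(=O)c3ccc(N)cc3)[nH]n2)cc1` gives 102% in this assay. Compound 3 `COc1ccc(-c2cc(/C=C/C(=O)c3ccc(N)cc3)[nH]n2)cc1OC` carries methoxy in place of hydrogen on an aromatic carbon and gives 92% in this assay; the step is a number 10 percentage points lower from compound 1 to compound 3 (within the scatter). Compound 2 `COc1ccc(C(=O)/C=C/c2cc(-c3cc(OC)c(OC)c(OC)c3)n[nH]2)cc1OC` gives 77% in this assay, the lowest of the three numbers; the difference between its core and the core of compound 1 is not broken down here.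

Compound 4 `COc1cc(C(=O)/C=C/c2cc(-c3cc(OC)c(OC)c(OC)c3)n[nH]2)cc(OC)c1OC` has not yet been measured. It differs from compound 2 by methoxy in place of hydrogen on an aromatic carbon. Among the compounds with values here, this is the same kind of change as the one from compound 1 to compound 3, but not the same: in compound 4 the entering methoxy sits ortho to a methoxy group, meta to a large group and also meta to a methoxy group, while in compound 3 the surroundings are ortho to a methoxy group and meta to a large group only.

A step of similar size is expected because the earlier step of a number 10 percentage points lower from compound 1 to compound 3 (within the scatter) stayed within the scatter. The expected step is a number 7 percentage points lower from compound 2 to compound 4 (within the scatter). Compound 4 is therefore estimated to give 70% in this assay, between 55% and 85%.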

Compound 4, a percentage reported as activity, at one concentration (the size of the read-out at that concentration, not a potency): 78%
Compound 4: middle estimate off by 8 percentage points, on the low side; low and high end bracket the measured number.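

Putting methoxy in place of hydrogen on an aromatic carbon of the core of compound 2 gives a number 1 percentage points higher from compound 2 to compound 4 (within the scatter) in this assay. Set beside the same change on the core of compound 1, the two steps agree as far as these data can tell: the same change on two cores in this assay, a number 10 percentage points lower (within the scatter) from compound 1 to compound 3 and a number 1 percentage points higher (within the scatter) from compound 2 to compound 4, 11 percentage points apart, within the scatter of two such steps On both cores, then, this change left the read-out within the usual scatter, but that does not show that methoxy has no effect at all or that it would behave the same way on a further core, as there are only two pairs, the entering methoxy has different surroundings in each, and every number comes from a single concentration.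

The compounds shown leave open whether a different group at this place, such as a hydroxyl, a carboxylic acid or a longer chain like ethoxy, would move the number beyond the scatter. They also leave open how these compounds would compare at other concentrations.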